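Methyl-to-phenyl step repeated on the mirror-image core

This account rests on a few compounds, and the source may have more. Where it says the series, first, only, none or still open, it means among the compounds named here.

The series holds compound 1 `O[C@@H]1[C@@H](O)CN[C@H]1c1ccc(-c2ccccc2)cc1`, compound 2 `Cc1ccc([C@@H]2NC[C@H](O)[C@H]2O)cc1`, compound 3 `Cc1ccc([C@H]2NC[C@@H](O)[C@@H]2O)cc1` and the still unmeasured compound 4 `O[C@H]1[C@H](O)CN[C@@H]1c1ccc(-c2ccccc2)cc1`. In an assay on isolated protein for inhibition of alpha-mannosidase (Canavalia ensiformis), read by spectrophotometry, tested at 1000 uM (on this read-out higher numbers stand for more inhibition at the one concentration tested (going by the name of the read-out) and lower numbers for less inhibition), compound 1 gives 0%, compound 2 gives 0.4% and compound 3 gives 0%; all three sit within the usual scatter of one another, so no order among them can be read.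

Two measured steps exist. Going from compound 2 to compound 1 the change is phenyl in place of methyl on an aromatic carbon, and it made a number 0.4 percentage points lower from compound 2 to compound 1 (within the scatter). Within the data shown here, the other step, a number 0.4 percentage points lower from compound 2 to compound 3 (within the scatter), is the only one on which any evidence bears, namely (the fact that compounds 2 and 3 differ only in the configuration as drawn).

Compound 4 stands to compound 3 exactly as compound 1 stands to compound 2: phenyl in place of methyl on an aromatic carbon. The place of the change is the same in both pairs word for word, so this is the same change, made twice in all. The two cores on which it is made differ by the two compounds have the same atoms and bonds and differ only in configuration as drawn: 3 of 3 stereo elements differ (all stereocentres are inverted: mirror images); a stereocentre at a saturated ring carbon is drawn S in compound 2 and R in compound 3; a stereocentre at a saturated ring carbon is drawn S in compound 2 and R in compound 3; a stereocentre at a saturated ring carbon is drawn S in compound 2 and R in compound 3.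

Given that compound 3 gives 0% and that the same change produced a number 0.4 percentage points lower from compound 2 to compound 1 (within the scatter), the step from compound 3 to compound 4 is expected to be about no change at the digits printed from compound 3 to compound 4 (within the scatter) in this assay. Compound 4 is accordingly estimated at 0%, with a likely span from -5% to 8%.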

Compound 4, a percentage reported as inhibition, at one concentration (the size of the read-out at that concentration, not a potency): 0%
Beside the measured number, compound 4's estimate shows no gap at the digits printed; measured number inside the range.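

In this assay, phenyl in place of methyl on the aromatic carbon gave no change at the digits printed from compound 3 to compound 4 (within the scatter), and the two occurrences of this change agree: the same change on two cores in this assay, a number 0.4 percentage points lower (within the scatter) from compound 2 to compound 1 and no change at the digits printed (within the scatter) from compound 3 to compound 4, 0.4 percentage points apart, within the scatter of two such steps

The mirror-image pair carrying phenyl gave no change at the digits printed from compound 1 to compound 4 (within the scatter), and the relation between its members is plain: the fact that compounds 1 and 4 differ only in the configuration as drawn

This agreement is only between steps that start at the bottom of the read-out, with compound 3 at 0% and compound 2 at 0.4%, so a drop in inhibition could hardly have shown, and nothing here shows that the change would carry over in the same way on a core with clear inhibition.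

Still open, going by these compounds, is whether any other group on the same aromatic carbon, such as an amine, a carboxylic acid or a longer chain, would give a number that stands clear of the scatter in this assay. Also open, on these data alone, is how the four compounds would read against an alpha-mannosidase from another source, since the present numbers speak for this one enzyme alone.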